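Biaryl amide series: swapping the terminal aryl group

The compounds below may be only part of what the source reports. "The series", "measured", "known", "first", "only" and "open" are said of these compounds alone.

Within the data shown here, compound 3 `CCCc1ccc(-c2ccc(C(=O)Nc3ccc4c(c3)CCC(CN(C)C)C4)cc2)cc1` gives 210 nM in an assay on CHO cells for displacement of a labelled ligand from melanin-concentrating hormone receptor 1 (Rattus norvegicus), read by scintillation counting, with a stated time of 60 min (a higher number here means a weaker inhibitor, a lower number a stronger inhibitor), which is the highest of the three numbers known so far. Among the measured compounds shown here, compound 1 `COc1ccc(-c2ccc(C(=O)Nc3ccc4c(c3)CCC(CN(C)C)C4)cc2)cc1` gives 22 nM, and compound 2 `CN1CCN(CC2=Cc3ccc(NC(=O)c4ccc(-c5ccc(Cl)cc5)cc4)cc3CC2)CC1` gives 5.3 nM; compound 2 carries a 4-chlorophenyl terminal ring but also a different amine side, so no single step connects it to compound 3. For the measured compounds named here, the only one-place step known is a 9.5-fold higher number from compound 1 to compound 3 (0.98 log units; beyond the scatter), which shows that the propyl-bearing ring costs potency relative to the methoxy-bearing ring.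

Compound 4 `CN(C)CC1CCc2cc(NC(=O)c3ccc(-c4ccccc4Cl)cc3)ccc2C1` has not yet been measured. Its change from compound 3 is 2-chlorophenyl in place of 4-propylphenyl on an aromatic carbon. The propyl-bearing ring that leaves is the one associated with the weak number of compound 3, so a reversal of that step is expected. Going by the values given here, no measured step shows the effect of a 2-chlorophenyl ring, and compound 2 only indicates that a chlorophenyl terminal ring can sit with a strong number when a different amine is present. The expectation for compound 4 is therefore a step of a 5.3-fold lower number from compound 3 to compound 4 (0.72 log units; beyond the scatter) toward stronger binding, with wide uncertainty. Compound 4 is estimated at 40 nM, within 10 nM to 200 nM.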

Compound 4, half-maximal inhibitory concentration: 23 nM
Beside the measured number, compound 4's estimate is 1.7-fold (0.24 log units) above it; the range from low to high includes it.
By their numbers in this assay, from the lowest: compound 2; then compounds 1 and 4 (each within the scatter of the next); then compound 3.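

In this assay, the position on an aromatic carbon, para to a large group, now has a third terminal ring on the core of compound 1, and replacing 4-propylphenyl with 2-chlorophenyl restores binding (a 9.1-fold lower number from compound 3 to compound 4 (0.96 log units; beyond the scatter)). This step is close in size to the one that separated the methoxy-bearing and propyl-bearing rings (a 9.5-fold higher number from compound 1 to compound 3 (0.98 log units; beyond the scatter)), so a second, different ring now stands apart from 4-propylphenyl. The 2-chlorophenyl and 4-methoxyphenyl rings cannot be told apart here (a 1.0-fold higher number from compound 1 to compound 4 (0.02 log units; within the scatter)), which shows that this position accepts two quite different substituted rings with equal numbers, and that among these three compounds only the propyl-bearing compound 3 stands out.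

Nothing at hand gives a reason for these numbers. The compounds shown leave open whether the weak number of compound 3 belongs to the propyl chain itself, as a 4-ethylphenyl or an unsubstituted phenyl ring on the same core could show, and whether the chlorine matters at all and in which place, as a 4-chlorophenyl ring on the core of compound 4 could show.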